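Chalcone Series: From Nitrophenyl to Aminopyrimidinyl Ketone

The compounds below may be only part of what the source reports. "The series", "measured", "known", "first", "only" and "open" are said of these compounds alone.

In a functional assay on NCI-H1299 cells (Homo sapiens) for antiproliferative activity, read by XTT assay, with a stated time of 72 h (on this read-out lower numbers stand for stronger inhibition and higher numbers for weaker inhibition), compound 1 `COc1ccc(-c2cc3ccccc3nc2/C=C/C(=O)c2ccc(OC)cc2OC)cc1` gives 3770 nM, and compound 2 `COc1ccc(-c2cc3ccccc3nc2/C=C/C(=O)c2ccc([N+](=O)[O-])cc2)cc1` gives 770 nM, the lowest of the two numbers. The only step shown, a 4.9-fold lower number from compound 1 to compound 2 (0.69 log units; beyond the scatter), comes from changing the group on the carbonyl carbon. Compound 3 `COc1ccc(-c2cc3ccccc3nc2/C=C/C(=O)c2cnc(N)nc2C)cc1` differs from compound 2 by 2-amino-4-methylpyrimidin-5-yl in place of 4-nitrophenyl on a carbonyl carbon. No measured step covers this particular change; the one step shown tells only that swapping the group at this position can move the number beyond the scatter. Compound 3 is therefore expected to give 2000 nM, within 500 nM to 8000 nM. This estimate means an expected step of a 2.6-fold higher number from compound 2 to compound 3 (0.41 log units; beyond the scatter), upward but uncertain.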

Compound 3, half-maximal inhibitory concentration: > 10000 nM
Compound 3: only a limit was reported; the forecaster's own chance of this, stated with the estimate: 10%; at least 5.0-fold (0.69 log units) between middle value and limit.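

Compound 3 reaches a limit of the read-out, not a measured number, in this assay: the limit of > 10000 nM in this assay, at which 1 of the 3 values shown sits.

This position can therefore do more than shift the number modestly: 2-amino-4-methylpyrimidin-5-yl brings an at least 12-fold higher number from compound 2 to compound 3 (1.11 log units; beyond the scatter), and set against 2,4-dimethoxyphenyl it brings an at least 2.6-fold higher number from compound 1 to compound 3 (0.42 log units; beyond the scatter). Both phenyl groups on the carbonyl carbon give measured numbers, whereas the one ring with hetero atoms shown gives only a limit.

On these data alone, the ring nitrogens, the amino group and the methyl group all enter together, so which of them matters stays open. An aminophenyl group or a plain pyrimidine ring at this place would help separate them.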